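Varying the Amine Terminus on a Shared Core

The source may report more compounds than this note shows. Statements on the series, on what has been measured and on what is new or still open speak of the compounds shown alone.

compound 1 `CC(=O)Oc1ccc(C(=O)Nc2cc3ccc(OCC4CCCN(C)C4)c(C)c3oc2=O)cc1CC=C(C)C`: 740 nM
compound 2 `CC(=O)Oc1ccc(C(=O)Nc2cc3ccc(OCC4CCN(C)C4)c(C)c3oc2=O)cc1CC=C(C)C`: 880 nM
compound 3 `CC(C)=CCc1cc(C(=O)Nc2cc3ccc(OCCCNCC(C)C)c(C)c3oc2=O)ccc1O`: 1030 nM

In a functional assay on SK-BR-3 cells (Homo sapiens) for antiproliferative activity (a higher number here means a weaker inhibitor, a lower number a stronger inhibitor), compound 3 sits at the upper end of the three numbers, yet its distance to compound 2 and to compound 1 lies within the scatter. Compound 4 `CC(C)=CCc1cc(C(=O)Nc2cc3ccc(OCCCN(C)C4CCCCC4)c(C)c3oc2=O)ccc1O` differs from compound 3 in one place: cyclohexyl(methyl)amino in place of isobutylamino on a saturated chain carbon, three bonds along the chain from an oxygen on an aromatic ring. Among the measured compounds shown here, the only measured step, a 1.2-fold higher number from compound 1 to compound 2 (0.08 log units; within the scatter), also alters the amine-bearing group and stayed within the scatter; no step exchanges a secondary amine for a tertiary one with a ring. The expectation for compound 4 is therefore no shift beyond the scatter, a 1.0-fold lower number from compound 3 to compound 4 (0.01 log units; within the scatter). Compound 4 is estimated at 1000 nM, with a range from 400 nM to 2500 nM.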

Compound 4, half-maximal inhibitory concentration: 970 nM
Beside the measured number, compound 4's estimate is 1.0-fold (0.01 log units) above it; the measured number falls inside the stated range.
By their numbers in this assay, from the lowest: compounds 1, 2, 4 and 3 (each within the scatter of the next).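

In this assay the exchange of isobutylamino for cyclohexyl(methyl)amino gives a 1.1-fold lower number from compound 3 to compound 4 (0.03 log units; within the scatter). The group at this place thus takes on a six-membered non-aromatic ring of carbon only and goes to 0 hydrogen-bond donors, with no shift beyond the scatter. The earlier step, by contrast, only exchanged one ring-bearing amine for another.

On these data alone, whether a carboxylic acid, an amide or a longer chain at this place would leave the number equally unmoved stays open. Nothing available bears on why the number held.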